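A few compounds are considered here, and "the series" means these few. Any claim that something is new, unique, unknown or untested is made for them only; others in the source may bear on it.

Among the measured compounds shown here, compound 2 `O=C([C@@H]1C[C@H]1F)N1CC2CC(C1)N2` gives 870 nM in an assay on SH-EP1 cells for agonist activity at Neuronal acetylcholine receptor; alpha4/beta2 (Homo sapiens), read by FLIPR and calcium flux (on this read-out higher numbers stand for an effect only at larger amounts of compound and lower numbers for an effect already at smaller amounts), the lowest of the two numbers measured so far. For the measured compounds named here, compound 1 `CC(=O)N1CC2CC(C1)N2` gives 9700 nM, and the only measured step, an 11-fold lower number from compound 1 to compound 2 (1.05 log units; beyond the scatter), came from exchanging a methyl for a 2-fluorocyclopropyl on the carbonyl carbon. Compound 3 `C[C@@H]1C[C@@H]1C(=O)N1CC2CC(C1)N2` takes a smaller step away from compound 2: a group of 4 heavy atoms (4 carbon; one three-membered non-aromatic ring of carbon only) in place of a group of 4 heavy atoms (3 carbon, 1 fluorine; one three-membered non-aromatic ring of carbon only), on a carbonyl carbon. Going by the values given here, no measured pair speaks directly to trading the fluorine of that ring for a methyl, so the expectation rests on the observation that the three-membered ring, which separated compound 1 from compound 2 by a large step, is kept in compound 3. Compound 3 is therefore expected to stay near compound 2, with the change estimated as a 1.7-fold higher number from compound 2 to compound 3 (0.24 log units; within the scatter), a step not beyond the scatter. The estimate for compound 3 is 1500 nM, ranging from 400 nM to 6000 nM.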

Compound 3, half-maximal effective concentration: 3800 nM
Compound 3: middle estimate off by 2.5-fold (0.40 log units), on the low side; low and high end bracket the measured number.
By their numbers in this assay, from the lowest: compound 2; then compound 3; then compound 1.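

In this assay, keeping the three-membered ring is not enough to hold the value: replacing the 2-fluorocyclopropyl on the carbonyl carbon with the all-carbon group of the same heavy-atom count gives a 4.4-fold higher number from compound 2 to compound 3 (0.64 log units; beyond the scatter), so what the ring carries matters at this position. The all-carbon group still improves on the methyl, with a 2.6-fold lower number from compound 1 to compound 3 (0.41 log units; beyond the scatter), but this is a smaller change than an 11-fold lower number from compound 1 to compound 2 (1.05 log units; beyond the scatter), so only part of that earlier step survives without the fluorine. Nothing available explains why the two ring-bearing groups differ.

The compounds shown leave open whether an open chain such as isopropyl could match the three-membered ring on the carbonyl carbon. They also leave open how a hydroxyl or an amine on that ring would compare with the fluorine, and whether other stereoisomers of these groups would behave alike.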